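Replacing 1H-indol-6-yl with 3-methylphenyl on the shared core

A few compounds are considered here, and "the series" means these few. Any claim that something is new, unique, unknown or untested is made for them only; others in the source may bear on it.

Among the compounds with values here, in a functional assay on B16-F0 cells (Mus musculus) for inhibition, read by CCK-8 assay, with a stated time of 48 h (a higher number here means a weaker inhibitor, a lower number a stronger inhibitor), compound 3 `COc1cc(-c2ccnc3cc(-c4ccc5cc[nH]c5c4)nn23)cc(OC)c1OC` gives 55 nM, the lowest of the three numbers measured so far, which makes it the strongest inhibitor of the set. Compound 1 `COc1cc(-c2ccnc3cc(-c4ccc(F)cc4)nn23)cc(OC)c1OC` gives 4540 nM, and compound 2 `COc1cc(-c2ccnc3cc(-c4ccccc4)nn23)cc(OC)c1OC` gives 4730 nM.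

The unmeasured compound 4 `COc1cc(-c2ccnc3cc(-c4cccc(C)c4)nn23)cc(OC)c1OC` differs from compound 3 at a single aromatic carbon: 3-methylphenyl in place of 1H-indol-6-yl on an aromatic carbon. Within the data shown here, two measured steps concern that same carbon, an 83-fold lower number from compound 1 to compound 3 (1.92 log units; beyond the scatter) and an 86-fold lower number from compound 2 to compound 3 (1.93 log units; beyond the scatter). Both are large, and both arrive at 1H-indol-6-yl. Read in reverse, they suggest that giving up this group for a substituted phenyl loses most of the advantage of compound 3. No methyl-bearing phenyl has been measured. The only substitution on the phenyl tested so far, fluoro against hydrogen, made no difference beyond the scatter, a 1.0-fold higher number from compound 1 to compound 2 (0.02 log units; within the scatter). A single methyl group is therefore not expected to recover much. In this assay, a large upward move is expected, with the estimate being a 64-fold higher number from compound 3 to compound 4 (1.80 log units; beyond the scatter), close in size to the two reversed steps. For compound 4 the estimated value is 3500 nM, with an expected range from 1200 nM to 9000 nM.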

Compound 4, half-maximal inhibitory concentration: 2220 nM
Beside the measured number, compound 4's estimate is 1.6-fold (0.20 log units) above it, and the stated range covers the measured number.
By their numbers in this assay, from the lowest: compound 3; then compound 4; then compounds 1 and 2 (each within the scatter of the next).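

With compound 4, the position shows that a methyl-bearing phenyl also stays far from the indole: in this assay there is a 40-fold higher number from compound 3 to compound 4 (1.61 log units; beyond the scatter), so the large gap is not confined to the plain and 4-fluoro phenyl groups. Within the data shown here, it also shows for the first time that the phenyl responds to a substituent, with a 2.1-fold lower number from compound 2 to compound 4 (0.33 log units; beyond the scatter) for the added methyl and a 2.0-fold lower number from compound 1 to compound 4 (0.31 log units; beyond the scatter) for the exchange of 4-fluorophenyl for 3-methylphenyl, both modest yet beyond the scatter, whereas fluoro against hydrogen had not moved the number beyond it. No measurement bearing on the reason for either move is available here.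

Leaving 1H-indol-6-yl removes the five-membered aromatic ring and the hydrogen-bond donor together, so these compounds cannot separate the two, and a benzofuran-6-yl group, which keeps both rings without the ring hydrogen on nitrogen, would address that question. They also leave open whether the modest gain is particular to methyl or extends to a longer chain such as ethyl, or to a methoxy group or an amine on the phenyl.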